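The compounds below may be only part of what the source reports. "The series", "measured", "known", "first", "only" and "open" are said of these compounds alone.

Working notes on the series.

Compound 1 `C[C@]1(C(=O)O)CC[C@H](C(=O)N2CC[C@](c3ccc(C(F)(C(F)(F)F)C(F)(F)F)cc3)(S(=O)(=O)c3ccc(F)cc3)C2)CC1` carries a 4-carboxy-4-methylcyclohexyl group on the carbonyl carbon of the shared core. In an ADME assay on microsomes from liver (Mus musculus) for metabolic stability, with a stated time of 10 min (on this read-out lower numbers stand for a less stable compound and higher numbers for a more stable compound), compound 1 gives 93%, a high remaining fraction. Compound 2 `CC[C@]1(C(=O)O)CC[C@H](C(=O)N2CC[C@](c3ccc(C(F)(C(F)(F)F)C(F)(F)F)cc3)(S(=O)(=O)c3ccc(F)cc3)C2)CC1` is the ethyl counterpart of compound 1; in this assay compound 2 has no number, its entry standing as "not determined" (no result reported), so compound 2 cannot be placed against compound 1 on this read-out. Compound 3 `CC1(C(=O)N2CC[C@](c3ccc(C(F)(C(F)(F)F)C(F)(F)F)cc3)(S(=O)(=O)c3ccc(F)cc3)C2)CCS(=O)(=O)CC1` replaces the carboxycyclohexyl group with a methyl-bearing dioxothianyl group, and in this assay compound 3 likewise has no number, its entry standing as "not determined" (no result reported). Only compound 1 anchors the series on this read-out.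

Compound 4 `CCC1(C(=O)N2CC[C@](c3ccc(C(F)(C(F)(F)F)C(F)(F)F)cc3)(S(=O)(=O)c3ccc(F)cc3)C2)CCS(=O)(=O)CC1` is the unmeasured member. The change from compound 2 to compound 4 is 4-ethyl-1,1-dioxothian-4-yl in place of 4-carboxy-4-ethylcyclohexyl on a carbonyl carbon. Within the data shown here, no measured step between compounds exists on this read-out, so the size of the step from compound 2 to compound 4 cannot be read from the data. The expectation is a moderate fall in this assay relative to the fraction seen for compound 1, 93%, rather than a change within the scatter only. Compound 4 is estimated at 70%, with a range of 40% to 95%.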

Compound 4, percent of the compound remaining: 0%
Estimate against measurement, compound 4: 70 percentage points above; the measured number lies below the stated range.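

At the carbonyl carbon whose other neighbours are the amide-type nitrogen in a ring, 4-ethyl-1,1-dioxothian-4-yl in place of 4-carboxy-4-methylcyclohexyl gives a number 93 percentage points lower from compound 1 to compound 4 (beyond the scatter) in this assay. Among these compounds, this is the first comparison on this read-out, and it shows that the group at this place is not interchangeable: with the shared core unchanged, the high remaining fraction of compound 1 does not carry over to compound 4. The change has several parts, since the carboxy group and the all-carbon ring leave while a ring with a sulfur atom enters and the methyl gives way to ethyl, and nothing measured here bears on the reason for the fall.

The steps that involve compound 2 or compound 3 cannot be read, so the part played by ethyl against methyl stays apart from that of the ring and its substituent. Also open, from the compounds shown here alone, is whether the 4-ethyl-1,1-dioxothian-4-yl result would hold with a hydroxyl group or a primary carboxamide in place of the carboxy group of 4-carboxy-4-methylcyclohexyl.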